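Swapping the amide-side bicycle for a dimethyltriazole

The compounds below may be only part of what the source reports. "The series", "measured", "known", "first", "only" and "open" are said of these compounds alone.

For the measured compounds named here, compound 3 `CCOc1ncc(-c2nc(C(F)(F)F)sc2N2CCN(C(=O)Cn3ccc4cccnc43)[C@H](C)C2)cn1` is one of three compounds measured in a functional assay on CHO-K1 cells for antagonist activity at C-X-C chemokine receptor type 3 (Homo sapiens), read by FLIPR, with a stated time of 10 min; a higher number here means a weaker inhibitor, a lower number a stronger inhibitor. Compound 3 gives 3.8 nM, the second highest of the three numbers. Its nearest neighbour is compound 1 `C[C@@H]1CN(c2sc(Br)nc2-c2nc3ccccc3[nH]2)CCN1C(=O)Cn1cnc2cccnc21`, which gives 2.8 nM in this assay, a gap within the scatter. Going by the values given here, the furthest is compound 2 `C[C@@H]1CN(c2sc(CO)nc2-c2nc3ccccc3[nH]2)CCN1C(=O)Cn1cnc2cccnc21`, which gives 171 nM; the only measured single-point step, a 61-fold higher number from compound 1 to compound 2 (1.79 log units; beyond the scatter), separates those two.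

Compound 4 `CCOc1ncc(-c2nc(C(F)(F)F)sc2N2CCN(C(=O)Cn3nc(C)nc3C)[C@H](C)C2)cn1` differs from compound 3 at a different place: a group of 7 heavy atoms (4 carbon, 3 nitrogen; one five-membered aromatic ring with 3 hetero atoms) in place of a group of 9 heavy atoms (7 carbon, 2 nitrogen; one five-membered aromatic ring with 1 hetero atom, one six-membered aromatic ring with 1 hetero atom), on a saturated chain carbon bound to a carbonyl carbon. No measured step touches this part of the molecule, since the one step shown changes a group on the aromatic carbon of the shared core, not the group on the saturated chain carbon bound to the carbonyl carbon. With nothing to anchor it, the expectation is a modest weakening in this assay, a step of a 2.6-fold higher number from compound 3 to compound 4 (0.42 log units; beyond the scatter), kept within a wide range. Compound 4 is therefore estimated at 10 nM, with a range from 2 nM to 50 nM.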

Compound 4, half-maximal inhibitory concentration: 7 nM
The estimate for compound 4 lay 1.4-fold (0.15 log units) above the measured number; the range from low to high includes it.
By their numbers in this assay, from the lowest: compounds 1, 3 and 4 (each within the scatter of the next, the first and the last beyond it); then compound 2.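

In this assay, putting 3,5-dimethyl-1H-1,2,4-triazol-1-yl in place of the group with one five-membered and one six-membered aromatic ring, on a saturated chain carbon bound to a carbonyl carbon, gives a 1.8-fold higher number from compound 3 to compound 4 (0.27 log units; within the scatter), so the two compounds cannot be told apart here. For the compounds shown here, this is the first measured change at this place, and it shows that the number survives the loss of the six-membered ring and a change to a smaller group with more ring nitrogens. Nothing available here explains why the number holds.

From the compounds shown here alone, it remains open whether a carboxylic acid or a dimethylamino group at this place would keep the number. The compounds shown also leave open whether the two methyl groups on the triazole matter, and whether the same swap behaves alike with the bromo group of compound 1 on the shared core.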